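Shortening the ether chain of compound 1 to a methoxy group

A few compounds are considered here, and "the series" means these few. Any claim that something is new, unique, unknown or untested is made for them only; others in the source may bear on it.

Measured so far:
- Compound 1, `CN(C)CCCOc1ccc(Nc2nccc(-c3cccnc3)n2)cc1`: 600 nM
- Compound 2, `COc1ccccc1Nc1nccc(-c2cccnc2)n1`: 9800 nM
- Compound 3, `CCc1ccc(Nc2nccc(-c3cc(C)oc3C)n2)cc1`: 19200 nM

All three compounds were tested in a functional assay for inhibition, with Homo sapiens as the target; a lower number here means a stronger inhibitor, a higher number a weaker inhibitor. On the numbers shown, compound 1 stands lowest, so it is the strongest inhibitor of the three; compound 2 gives a clearly higher number, and compound 3 a higher one still, both gaps lying beyond the usual scatter. For the measured compounds named here, compound 2 is the only other compound to carry a methoxy group on the aromatic ring attached to the shared core, while compound 3 carries a different ring on the core and an ethyl group on that aromatic ring.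

Compound 4, `COc1ccc(Nc2nccc(-c3cccnc3)n2)cc1`, has not yet been measured. It differs from compound 1 in one place: hydrogen in place of 2-(dimethylamino)ethyl on a saturated chain carbon bound to an oxygen on an aromatic ring. The long chain with its terminal basic nitrogen is thus cut back to a plain methoxy group, while everything else in compound 1 is kept.

Going by the values given here, no measured pair differs in exactly this way, so the size of the step has to be inferred. Because compound 2, which also carries a methoxy group, gives 9800 nM, the step is expected to go toward a higher number, beyond the scatter. The expected step of a 5.0-fold higher number from compound 1 to compound 4 (0.70 log units; beyond the scatter) is estimated as a moderate loss in this assay. Compound 4 is therefore expected to give about 3000 nM, within a range from 800 nM to 12000 nM.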

Compound 4, half-maximal inhibitory concentration: 1700 nM
Estimate against measurement, compound 4: 1.8-fold (0.25 log units) above; low and high end bracket the measured number.
By their numbers in this assay, from the lowest: compound 1; then compound 4; then compounds 2 and 3 (each within the scatter of the next).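

For the compounds shown here, this step is the first comparison in which only the group at this position changes, since the earlier compounds differ from one another in more than one place. In this assay, cutting 3-(dimethylamino)propoxy back to methoxy gives a 2.8-fold higher number from compound 1 to compound 4 (0.45 log units; beyond the scatter), so removing the 2-(dimethylamino)ethyl part of the chain costs some inhibition, though the step is modest. Compound 4 still gives a measurable number without that part, so the long chain is not required for inhibition in this series, and nothing measured here gives a reason for the step.

The compounds shown cannot tell whether the difference belongs to the amine at the end of the chain or simply to the length of the chain, and a plain propoxy group, with the same chain but no amine, would separate the two. A shorter 2-(dimethylamino)ethoxy chain, or a ring amine such as morpholine at the chain end, would further show how much the chain length and the form of the amine each count.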